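The compounds below may be only part of what the source reports. "The series", "measured", "known", "first", "only" and "open" are said of these compounds alone.

Measured in a physicochemical assay for lipophilicity, measured as octanol-water partition; on this read-out higher numbers stand for higher lipophilicity and lower numbers for lower lipophilicity:
Compound 1 (`CC(C)[C@@H]1CC[C@@H](C)C[C@H]1OC(=O)c1ccc(Cl)cc1Cl`): 5.86
Compound 2 (`CCC(=O)O[C@@H]1C[C@H](C)CC[C@H]1C(C)C`): 3.54
Compound 3 (`CC(C)[C@@H]1CC[C@@H](C)C[C@H]1OC(=O)c1ccccc1Cl`): 5.34

Compound 2 stands lowest of the three, and its gaps to both others lie beyond the scatter. Compound 4 (`CC(C)[C@@H]1CC[C@@H](C)C[C@H]1OC(=O)CCl`) differs from it by one change (chloro in place of methyl on a saturated chain carbon bound to a carbonyl carbon), chloro in place of methyl on a saturated chain carbon bound to a carbonyl carbon. Within the data shown here, the only measured step (a number 0.52 log units lower from compound 1 to compound 3 (beyond the scatter)) is modest, but it concerns hydrogen and chloro on an aromatic carbon, so it bears only loosely here. Among the measured compounds shown here, no measured step exchanges methyl for chloro. In this assay a small downward step, possibly within the scatter, is therefore expected. The expected change is a number 0.19 log units lower from compound 2 to compound 4 (within the scatter) by this estimate. Compound 4 is thus expected at 3.35 (estimated range 2.95 to 3.75).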

Compound 4, partition coefficient: 3.5
Beside the measured number, compound 4's estimate is 0.15 log units below it; the measured number falls inside the stated range.
By their numbers in this assay, from the lowest: compounds 4 and 2 (each within the scatter of the next); then compound 3; then compound 1.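

In this assay, chloro in place of methyl on a saturated chain carbon bound to a carbonyl carbon gives a number 0.04 log units lower from compound 2 to compound 4 (within the scatter), so at this position the two groups cannot be told apart on this read-out. Among the earlier compounds, chloro stood only on an aromatic carbon, where a number 0.52 log units lower from compound 1 to compound 3 (beyond the scatter) lay beyond the scatter. Nothing available explains the result at this position.

Going by these compounds, whether an amine, a carboxylic acid or a longer chain at this position would also stay within the scatter of compound 2 remains open. So does whether the exchange of methyl for chloro would read the same on another core.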